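This account rests on a few compounds, and the source may have more. Where it says the series, first, only, none or still open, it means among the compounds named here.

Of the compounds shown here, three sharing one core have been tested in a toxicity assay on HEK-293T cells (Homo sapiens) for cytotoxicity, read by MTT assay, with a stated time of 72 h; on this read-out lower numbers stand for stronger inhibition and higher numbers for weaker inhibition: compound 1 `O=C1c2c[n+]([O-])c3ccccc3c2C(=O)c2c1c1ccccc1n2Cc1cn(CC(O)CO)nn1`, compound 2 `CC1(C)OC[C@H](Cn2cc(Cn3c4c(c5ccccc53)C(=O)c3c[n+]([O-])c5ccccc5c3C4=O)nn2)O1` and compound 3 `O=C1c2c[n+]([O-])c3ccccc3c2C(=O)c2c1c1ccccc1n2Cc1cn([C@H]2C[C@H](O)[C@@H](CO)O2)nn1`. Compound 2 gives 100 nM and compound 1 gives 760 nM, while compound 3 gives 3600 nM, the highest number of the three and so the weakest effect on these cells.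

The untested compound 4 `O=C1c2c[n+]([O-])c3ccccc3c2C(=O)c2c1c1ccccc1n2Cc1cn([C@@H]2O[C@H](CO)[C@@H](O)[C@H](O)[C@H]2O)nn1` differs from compound 3 in one group, on an aromatic nitrogen of a five-membered aromatic ring with 3 nitrogen: 3,4,5-trihydroxy-6-(hydroxymethyl)oxan-2-yl takes the place of 4-hydroxy-5-(hydroxymethyl)oxolan-2-yl (3,4,5-trihydroxy-6-(hydroxymethyl)oxan-2-yl in place of 4-hydroxy-5-(hydroxymethyl)oxolan-2-yl on an aromatic nitrogen).

Going by the values given here, no measured step makes this exact swap, so the evidence is indirect. The closest is a 4.7-fold higher number from compound 1 to compound 3 (0.68 log units; beyond the scatter), a modest step, in which 4-hydroxy-5-(hydroxymethyl)oxolan-2-yl replaced 2,3-dihydroxypropyl. Related steps are a 7.6-fold lower number from compound 1 to compound 2 (0.88 log units; beyond the scatter), also modest, and a 36-fold higher number from compound 2 to compound 3 (1.56 log units; beyond the scatter), which is large. Among these three compounds, the number is lowest for compound 2, whose group carries no free hydroxy, and highest for compound 3. Among the compounds with values here, with only three compounds, this is a weak guide, and none of them carries the six-membered ring. A modest upward step is therefore expected, and the estimate is a 2.2-fold higher number from compound 3 to compound 4 (0.35 log units; beyond the scatter). For compound 4 the estimated value is 8000 nM, with an expected range from 2500 nM to 25000 nM.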

Compound 4, half-maximal inhibitory concentration: 940 nM
Estimate against measurement, compound 4: 8.5-fold (0.93 log units) above; the measured number lies below the stated range.
By their numbers in this assay, from the lowest: compound 2; then compounds 1 and 4 (each within the scatter of the next); then compound 3.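

In this assay the six-membered 3,4,5-trihydroxy-6-(hydroxymethyl)oxan-2-yl on the aromatic nitrogen gives a 3.8-fold lower number from compound 3 to compound 4 (0.58 log units; beyond the scatter) even though it carries more hydrogen-bond donors than the five-membered group it replaces, so among these compounds more hydroxy groups at this position do not simply mean a higher number. Set against the open chain, it gives a 1.2-fold higher number from compound 1 to compound 4 (0.09 log units; within the scatter) so 2,3-dihydroxypropyl and the six-membered group cannot be told apart here, and compound 3 alone stands out with the highest number of the four. The (2,2-dimethyl-1,3-dioxolan-4-yl)methyl group, with no free hydroxy, still gives the lowest number, and the change to the six-membered group is a 9.4-fold higher number from compound 2 to compound 4 (0.97 log units; beyond the scatter) on these cells.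

No measurement shown explains these shifts, and ring size and hydroxy count change together between compound 3 and compound 4, so their shares remain unknown. Also open, on these data alone, is whether an amine or a carboxylic acid in this place would bring the number close to that of compound 2 or to that of compound 3.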